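Methylating the Amino Group: From Compound 3 to Compound 4

This account rests on a few compounds, and the source may have more. Where it says the series, first, only, none or still open, it means among the compounds named here.

Measured so far:
- compound 1, `CN(C)c1nc(N)c(C(=O)Nc2ccccn2)nc1Cl`: 134 nM
- compound 2, `CC(C)Nc1nc(N)c(C(=O)Nc2ccccn2)nc1Cl`: 23 nM
- compound 3, `Nc1ncc(Cl)nc1C(=O)Nc1ccccn1`: 11 nM

All three compounds were tested in an assay on Ltk cells for inhibition of metabotropic glutamate receptor 5 (Homo sapiens), read by fluorescence; on this read-out lower numbers stand for stronger inhibition and higher numbers for weaker inhibition. Compound 3 stands lowest of the three; its nearest neighbour is compound 2, and the step of a 2.1-fold lower number from compound 2 to compound 3 (0.32 log units; beyond the scatter) lies beyond the scatter, as does the larger step of a 12-fold lower number from compound 1 to compound 3 (1.09 log units; beyond the scatter). Both steps, together with a 5.8-fold lower number from compound 1 to compound 2 (0.77 log units; beyond the scatter), concern one place on an aromatic carbon of the shared core, where hydrogen gives the lowest number and dimethylamino the highest.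

Compound 4, `CNc1ncc(Cl)nc1C(=O)Nc1ccccn1`, differs from compound 3 at another place: methyl in place of hydrogen on a nitrogen on an aromatic ring, so amino becomes methylamino. Among the compounds with values here, no measured step touches this nitrogen, so the earlier steps bear on it only indirectly; they show that a small group added to the core tended to raise the number modestly. Compound 4 is therefore expected to give a number near that of compound 3 or somewhat higher, a step of a 1.8-fold higher number from compound 3 to compound 4 (0.26 log units; within the scatter) in this assay. The estimate for compound 4 is 20 nM, with a range from 6 nM to 65 nM.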

Compound 4, half-maximal inhibitory concentration: 145 nM
Beside the measured number, compound 4's estimate is 7.3-fold (0.86 log units) below it, outside the stated range (above it).
By their numbers in this assay, from the lowest: compound 3; then compound 2; then compounds 1 and 4 (each within the scatter of the next).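

In this assay, the change of amino to methylamino gives a 13-fold higher number from compound 3 to compound 4 (1.12 log units; beyond the scatter), so this nitrogen responds strongly to a change of only one carbon. That step is clearly larger than a 2.1-fold lower number from compound 2 to compound 3 (0.32 log units; beyond the scatter), where a whole isopropylamino group gives way to hydrogen at the other place on the shared core. The size of an added group therefore does not set the size of the step across these compounds, and what was seen at one place does not carry over to this nitrogen. Nothing in the data explains why the number rises so far here. Still open, on these data alone, is whether a longer chain on this nitrogen, such as ethyl or propyl, raises the number further. Also open, as far as these compounds go, is whether the same methyl has a similar effect in compound 2, with its isopropylamino group in place.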